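The source may report more compounds than this note shows. Statements on the series, on what has been measured and on what is new or still open speak of the compounds shown alone.

Three compounds of a shared core, each carrying a nitrile-bearing chain on the same ring, have been tested in a functional assay on OVCAR-8 cells (Homo sapiens) for cytotoxicity, read by sulforhodamine B assay, with a stated time of 48 h, tested at 100 nM; a higher number here means a weaker effect of the compound at the concentration tested, a lower number a stronger effect. Compound 1 `COc1cc(C)cc(-c2c(-c3ccnc(-c4ccc(C(C)=O)cc4)c3)cnn2CC#N)c1` gives 85%. Compound 2 `COc1cc(C)cc(-c2nn(CC#N)cc2-c2ccc(-c3cccc(C(C)=O)c3)nc2)c1` gives 86%. Compound 3 `Cc1cc(O)cc(-c2nn(CC#N)cc2-c2ccnc(-c3ccc(Oc4ccccc4)cc3)c2)c1` gives 87%. The three numbers sit close together: the value of compound 1 is within the usual scatter of both the value of compound 2 and the value of compound 3, so none of the three can be set apart from the others, and all three show only a weak effect at the concentration used.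

The next compound, compound 4 `COc1cc(C)cc(-c2c(-c3ccnc(-c4ccc(N(C)C)cc4)c3)cnn2CC#N)c1`, differs from compound 1 in a single place: dimethylamino in place of acetyl on an aromatic carbon. Among the measured compounds shown here, no pair among the measured compounds shows a change of this kind, so there is no measured step to lean on. With every measured compound sitting at a similarly weak level, the expectation for this change is a step of no size beyond the scatter, no change at the digits printed from compound 1 to compound 4 (within the scatter), in either direction. On that basis compound 4 is estimated to give 85% in this assay, with a range from 68% to 100%.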

Compound 4, a percentage reported as activity, at one concentration (the size of the read-out at that concentration, not a potency): 11%
Estimate against measurement, compound 4: 74 percentage points above; measured number below the stated range.
By their numbers in this assay, from the lowest: compound 4; then compounds 1, 2 and 3 (each within the scatter of the next).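

The earlier compounds shown here offered no step to read, and their closely grouped numbers gave no sign that any part of the structure mattered. In this assay, changing 4-acetylphenyl to 4-(dimethylamino)phenyl gives a number 74 percentage points lower from compound 1 to compound 4 (beyond the scatter), so this one aromatic carbon is a place where the choice of group can decide between a weak and a strong effect at the concentration tested. The counted features do not separate the two groups: each has 3 heavy atoms, no ring, 0 hydrogen-bond donors and 1 hydrogen-bond acceptor, while the acetyl has a double bond and an oxygen, and the dimethylamino has a nitrogen.

Nothing shown here gives a measured reason for the size of this step. On these data alone, it also remains open whether dimethylamino is special or whether a plain amino group, a diethylamino group or a morpholine ring at the same carbon would do as well, and whether the same exchange would have a similar effect on the acetyl group of compound 2.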